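This account rests on a few compounds, and the source may have more. Where it says the series, first, only, none or still open, it means among the compounds named here.

Compound 1: `Cc1ccc2nc(Cl)c(/C=N/n3cc(-c4ccccc4)nc3N)cc2c1` — 48100 nM
Compound 2: `Nc1nc(-c2cccs2)cn1/N=C/c1cc2ccccc2nc1Cl` — > 50000 nM

The read-out here is a functional assay on MDA-MB-231 cells (Homo sapiens) for cytotoxicity, read by MTT assay, with a stated time of 48 h; on this read-out higher numbers stand for weaker inhibition and lower numbers for stronger inhibition. Compound 1 has a measured number in this assay, 48100 nM. Compound 2 stands differently: its entry in this assay, > 50000 nM, is a limit of the assay and not a number. the limit of > 50000 nM in this assay, at which 1 of the 2 values shown sits, describes where that entry lies.

Compound 3, `Cc1ccc2nc(Cl)c(/C=N/n3cc(-c4cccs4)nc3N)cc2c1`, is reached from compound 2 by one change: methyl in place of hydrogen on an aromatic carbon. Going by the values given here, no step between two measured compounds that differ in exactly one place is available, so nothing measured tells how large such a change is. Compound 1 also carries a methyl on its shared core and still sits close to the limit. The step from compound 2 to compound 3 is therefore expected to be small, a step that the limit leaves unreadable from compound 2 to compound 3, not beyond the scatter in either direction. Compound 3 is thus estimated at 55000 nM, with a range from 25000 nM to 120000 nM, and a fair chance that this assay again reports only a limit.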

Compound 3, half-maximal inhibitory concentration: > 50000 nM
Compound 3: only a limit was reported (the forecaster's own chance of this, stated with the estimate: 60%); the middle value does not contradict the limit.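

With the methyl on the six-membered aromatic ring, compound 3 still gives only a limit of the assay, not a number, in this assay: the limit of > 50000 nM in this assay, at which 2 of the 3 values shown sit.

The step for methyl in place of hydrogen cannot be read, as both of its ends are limits. With the methyl kept, thiophen-2-yl in place of phenyl gives an at least 1.0-fold higher number from compound 1 to compound 3 (0.01 log units; that floor lies within the scatter), so the true size of this swap could be small or larger.

Going by these compounds, how far compound 3 lies past its limit stays open, and with it the effect of the methyl itself. Also open, on these data alone, is whether an amine or a carboxylic acid on that same aromatic carbon would give a measurable number in this assay.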